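A few compounds are considered here, and "the series" means these few. Any claim that something is new, unique, unknown or untested is made for them only; others in the source may bear on it.

Compound 1 `Cc1ccc(-c2nc(CNc3ccc(C(=O)NO)cc3)n(-c3ccccc3)n2)cc1` gives in a functional assay on MGC-803 cells (Homo sapiens) for antiproliferative activity, read by MTT assay, with a stated time of 72 h (a higher number here means a weaker inhibitor, a lower number a stronger inhibitor), only a limit, > 20000 nM.
Compound 2 `O=C(NO)c1ccc(NCc2nc(-c3ccccc3Cl)nn2-c2ccccc2)cc1` gives in this assay only a limit, > 20000 nM.
Compound 3 `O=C(NO)c1ccc(NCc2nc(-c3ccccc3)nn2-c2ccc(F)cc2)cc1` gives in this assay 10500 nM.

Among the measured compounds shown here, of the three compounds measured so far, compound 3 is the only one that returns a number at all; the other two come back as limits, so compound 3 cannot be placed above or below them with any certainty, only noted as the one compound that is measurable here. For the measured compounds named here, the single measured step, a step that the two limits leave unreadable from compound 1 to compound 2, cannot be read in size because both of its ends sit at the limit of > 20000 nM in this assay, at which 2 of the 3 values shown sit, and it concerns a different ring of the shared core in any case.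

Compound 4 `O=C(NO)c1ccc(NCc2nc(-c3ccccc3)nn2-c2ccccc2)cc1` differs from compound 3 in one place: hydrogen in place of fluoro on an aromatic carbon. Going by the values given here, none of the measured steps touches this position, so there is no measured guide to the direction or size of the change. The expectation is therefore a step that stays within the usual scatter, and the step expected is a 1.3-fold higher number from compound 3 to compound 4 (0.12 log units; within the scatter). In this assay compound 4 is estimated at 14000 nM, with a range from 6000 nM to 30000 nM, and a real chance that only a limit is returned.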

Compound 4, half-maximal inhibitory concentration: 17700 nM
Estimate against measurement, compound 4: 1.3-fold (0.10 log units) below; the range from low to high includes it.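

Among the compounds shown here, the change from 4-fluorophenyl to phenyl, at a position no earlier step touched, shows up as a 1.7-fold higher number from compound 3 to compound 4 (0.23 log units; within the scatter) in this assay, so fluoro and hydrogen cannot be told apart here. Compound 4 also adds a second real number to the set, which gives the changes on the other ring of the shared core a measured end point. The step for chloro reads as an at least 1.1-fold lower number from compound 2 to compound 4 (0.05 log units; that floor lies within the scatter), and the step for methyl reads as an at least 1.1-fold lower number from compound 1 to compound 4 (0.05 log units; that floor lies within the scatter); each is only a floor within the scatter, since compound 1 and compound 2 both start from a limit: the limit of > 20000 nM in this assay, at which 2 of the 4 values shown sit.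

As far as these compounds go, whether another group at the position of the fluoro, such as an amine, a carboxylic acid or a methoxy group, would move the number beyond the scatter remains open. From the compounds shown here alone, the true distance of compound 1 and compound 2 from compound 4 also remains unknown, so neither the methyl nor the chloro group can yet be said to matter on that ring.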